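The source may report more compounds than this note shows. Statements on the series, on what has been measured and on what is new or still open speak of the compounds shown alone.

Working notes on the series, all read in a functional assay on HCT-116 cells (Homo sapiens) for inhibition, read by CCK-8 assay, with a stated time of 48 h; a higher number here means a weaker inhibitor, a lower number a stronger inhibitor. Compound 1 `COc1ccc(CN(C(=O)CSC(=S)N2CCN(C)CC2)c2cc(OC)c(OC)c(OC)c2)cc1` gives 2640 nM. Among the compounds with values here, compound 2 `COc1ccc(CN(C(=O)CSC(=S)N2CCc3cc(OC)ccc32)c2cc(OC)c(OC)c(OC)c2)cc1` gives 9810 nM, the higher and so the weaker of the two numbers measured so far.

The next compound is compound 3 `COc1ccc(CN(C(=O)CSC(=S)N2CCCc3cc(C)ccc32)c2cc(OC)c(OC)c(OC)c2)cc1`, which carries 6-methyl-1,2,3,4-tetrahydroquinolin-1-yl in place of 5-methoxy-2,3-dihydro-1H-indol-1-yl on a thiocarbonyl carbon. The rest of the structure stays as in compound 2.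

Within the data shown here, only one measured step bears on this place, a 3.7-fold higher number from compound 1 to compound 2 (0.57 log units; beyond the scatter), and it is modest. That step replaced 4-methylpiperazin-1-yl, a group much less like the other two than they are like each other. Among the measured compounds shown here, with that step as the only guide, a smaller change is expected for compound 3, possibly no more than the scatter. For the measured compounds named here, no measured step separates the change of ring size from the loss of the methoxy group, so the direction stays open.

The expected step is a 1.4-fold lower number from compound 2 to compound 3 (0.15 log units; within the scatter), a slight shift with little confidence in its sign. Compound 3 is estimated at 7000 nM, with an expected range of 2500 nM to 18000 nM.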

Compound 3, half-maximal inhibitory concentration: 5230 nM
The estimate for compound 3 lay 1.3-fold (0.13 log units) above the measured number; the range from low to high includes it.
By their numbers in this assay, from the lowest: compounds 1, 3 and 2 (each within the scatter of the next, the first and the last beyond it).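

In this assay, exchanging 5-methoxy-2,3-dihydro-1H-indol-1-yl for 6-methyl-1,2,3,4-tetrahydroquinolin-1-yl on the thiocarbonyl carbon gives a 1.9-fold lower number from compound 2 to compound 3 (0.27 log units; within the scatter), so this change cannot be told apart from repeat-measurement scatter. The comparison with 4-methylpiperazin-1-yl gives a 2.0-fold higher number from compound 1 to compound 3 (0.30 log units; within the scatter), so this place now holds two groups with a fused aromatic ring that differ differently from 4-methylpiperazin-1-yl: the gap remains beyond the scatter in a 3.7-fold higher number from compound 1 to compound 2 (0.57 log units; beyond the scatter), but not for compound 3, and the presence of such a ring does not by itself separate a compound from compound 1. No measurement in hand offers an explanation for these differences.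

The step from compound 2 to compound 3 changes the size of the non-aromatic ring and exchanges methoxy for methyl together, so neither change can be assigned a share of it. The compounds shown also leave open how this series reads with a morpholine or a diethylamine on the thiocarbonyl carbon, and whether either would stand apart from compound 1 by more than the scatter.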